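A few compounds are considered here, and "the series" means these few. Any claim that something is new, unique, unknown or untested is made for them only; others in the source may bear on it.

Measured so far in a functional assay (aorta) with Oryctolagus cuniculus as the target; a higher number here means a weaker inhibitor, a lower number a stronger inhibitor:

Compound 1, `OCc1ccc(-c2nn(Cc3ccccc3F)c3ccncc23)o1`: 9800 nM
Compound 2, `Cc1cnc(-c2nn(Cc3ccccc3F)c3ncccc23)nc1N`: 675000 nM

Of the two numbers, compound 2 gives the higher one in this assay, and its distance from compound 1 lies beyond the scatter of repeated measurements; compound 2 is thus the weaker inhibitor of the pair. Among the compounds with values here, no pair of measured compounds differs in a single place, so no step has been set for any one change.

Compound 3, `Nc1nc(-c2nn(Cc3ccccc3F)c3ncccc23)ncc1F`, has not yet been measured. It differs from compound 2 in one place: fluoro in place of methyl on an aromatic carbon, on an aromatic carbon of a six-membered aromatic ring with two nitrogens, ortho to an amino group. Within the data shown here, with no measured step of this kind to lean on, the expected step of a 1.4-fold lower number from compound 2 to compound 3 (0.13 log units; within the scatter) is small, in no certain direction, and probably not beyond the scatter. Compound 3 is therefore estimated to give about 500000 nM in this assay, with a range from 150000 nM to 2000000 nM.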

Compound 3, half-maximal inhibitory concentration: 478000 nM
Compound 3: the middle estimate sits 1.0-fold (0.02 log units) above what was measured, within the range that was stated.
By their numbers in this assay, from the lowest: compound 1; then compounds 3 and 2 (each within the scatter of the next).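

In this assay, the change from 4-amino-5-methylpyrimidin-2-yl to 4-amino-5-fluoropyrimidin-2-yl gives a 1.4-fold lower number from compound 2 to compound 3 (0.15 log units; within the scatter), so methyl and fluoro cannot be told apart at this position, ortho to an amino group. Within the data shown here, this is the first measured step at this place, and it shows that exchanging one of these single-atom groups for the other leaves no readable mark on the number. No measurement available here bears on why the two groups behave alike.

The compounds shown leave open whether plain hydrogen, chloro, methoxy or a longer alkyl chain at this same position would move the number beyond the scatter. They also leave open what would follow if the neighbouring amino group gave way to a hydroxyl or a methylamino group.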